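The source may report more compounds than this note shows. Statements on the series, on what has been measured and on what is new or still open speak of the compounds shown alone.

Measured so far in a functional assay on A549 cells (Homo sapiens) for antiproliferative activity, read by MTT assay, with a stated time of 72 h; a higher number here means a weaker inhibitor, a lower number a stronger inhibitor: compound 1 `O=C(Nc1ccc(Oc2ccnc3[nH]ccc23)cc1)c1cc2cccnc2n(-c2ccc(Br)cc2)c1=O` gives 280 nM; compound 2 `O=C(Nc1ccc(Oc2ccnc3[nH]ccc23)cc1)c1cc2cccnc2n(-c2ccc(Br)cc2F)c1=O` gives 1570 nM; compound 3 `O=C(Nc1ccc(Oc2ccnc3[nH]ccc23)c(F)c1)c1cc2cccnc2n(-c2ccccc2)c1=O` gives 190 nM.

Compound 2 differs from compound 1 by fluoro in place of hydrogen on an aromatic carbon, and this step gave a 5.6-fold higher number from compound 1 to compound 2 (0.75 log units; beyond the scatter). Compound 3 stands with the lowest number of the three, though its gap to compound 1 is within the scatter; the difference between the cores of compound 1 and compound 3 is not broken down here.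

Compound 4 `O=C(Nc1ccc(Oc2ccnc3[nH]ccc23)c(F)c1)c1cc2cccnc2n(-c2ccc(F)cc2)c1=O` differs from compound 3 by fluoro in place of hydrogen on an aromatic carbon. This is the same kind of change as that from compound 1 to compound 2, but the place differs: there the fluoro entered ortho to a large group and meta to a bromo group, here it enters para to a large group. Within the data shown here, the only measured example of this kind of change, a 5.6-fold higher number from compound 1 to compound 2 (0.75 log units; beyond the scatter), lost potency, but it sits at a different place, so only a small step is expected for compound 4, a 1.4-fold higher number from compound 3 to compound 4 (0.14 log units; within the scatter). Compound 4 is therefore estimated at 260 nM in this assay, between 100 nM and 750 nM.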

Compound 4, half-maximal inhibitory concentration: 62 nM
For compound 4 the middle estimate is 4.2-fold (0.62 log units) above the measured one; measured number outside the range, below it.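

In this assay, the step from phenyl to 4-fluorophenyl gave a 3.1-fold lower number from compound 3 to compound 4 (0.49 log units; beyond the scatter), so this change did not carry from one core to the other with the same direction or size: the same change on two cores in this assay, a 5.6-fold higher number (0.75 log units; beyond the scatter) from compound 1 to compound 2 and a 3.1-fold lower number (0.49 log units; beyond the scatter) from compound 3 to compound 4, 17-fold (1.24 log units) apart, beyond the scatter of two such steps. The two steps differ in more than the core, since the fluoro enters at a different place in each pair and compound 1 and compound 2 also carry a bromo group, so the data cannot separate these differences. Among these compounds, with only one pair on each side, they show that the outcome depends on context, not which difference is responsible.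

The compounds shown leave open whether a chloro, methyl or methoxy group para to a large group would behave like the fluoro of compound 4. They also leave open whether an amine at that place would be tolerated.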